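From piperidin-1-yl to (4-fluorophenyl)amino: an expected gain

The compounds below may be only part of what the source reports. "The series", "measured", "known", "first", "only" and "open" are said of these compounds alone.

Compound 1, `COc1ccc(Nc2cc(C)nc(SCc3nc4ccccc4[nH]3)n2)cc1`, gives 69800 nM in a functional assay on ECa-109 cells (Homo sapiens) for cytotoxicity, read by MTT assay, with a stated time of 72 h; on this read-out higher numbers stand for weaker inhibition and lower numbers for stronger inhibition.
Compound 2, `Cc1cc(N2CCCCC2)nc(SCc2nc3ccccc3[nH]2)n1`, gives only a limit of the assay, > 100000 nM.
Compound 3, `Cc1cc(NNC(N)=S)nc(SCc2nc3ccccc3[nH]2)n1`, likewise gives only a limit, > 100000 nM.

Compound 2 therefore stands at the ceiling of what was measured: its value is a limit rather than a number, and (the limit of > 100000 nM in this assay, at which 2 of the 3 values shown sit). The unmeasured compound 4, `Cc1cc(Nc2ccc(F)cc2)nc(SCc2nc3ccccc3[nH]2)n1`, differs from compound 2 in one place: (4-fluorophenyl)amino in place of piperidin-1-yl on an aromatic carbon. Among the measured compounds shown here, one measured step bears on this change, running in the opposite direction: an at least 1.4-fold higher number from compound 1 to compound 2 (0.15 log units; that floor lies within the scatter). Replacing a (4-methoxyphenyl)amino group by piperidin-1-yl pushed the value over the limit, so restoring a substituted phenylamino group is expected to bring it back to a readable number. The step that the two limits leave unreadable from compound 2 to compound 3 cannot be read and offers no guidance. Compound 1 carries (4-methoxyphenyl)amino where compound 4 carries (4-fluorophenyl)amino, so compound 4 is expected to land close to compound 1. The expected step is an at least 1.5-fold lower number from compound 2 to compound 4 (0.18 log units; that floor lies within the scatter). For compound 4 the estimate is 65000 nM, ranging from 25000 nM to 160000 nM.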

Compound 4, half-maximal inhibitory concentration: 69500 nM
Compound 4: the middle estimate sits 1.1-fold (0.03 log units) below what was measured; the range from low to high includes it.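

In this assay, fluoro in place of methoxy gives a 1.0-fold lower number from compound 1 to compound 4 (0.00 log units; within the scatter) and so leaves the two substituted phenylamino compounds indistinguishable. This second compound with a readable value suggests that a readable number is not specific to the (4-methoxyphenyl)amino group, and two further steps point the same way, namely an at least 1.4-fold lower number from compound 2 to compound 4 (0.15 log units; that floor lies within the scatter) and an at least 1.4-fold lower number from compound 3 to compound 4 (0.15 log units; that floor lies within the scatter) at this part of the molecule. Compound 2 and compound 3 each hold only a limit, so neither step gives a true size: the limit of > 100000 nM in this assay, at which 2 of the 4 values shown sit.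

On these data alone, it remains open whether a plain phenylamino group, a (4-chlorophenyl)amino group or a benzylamino group would give a value that differs from compound 1 by more than the scatter. The compounds shown also cannot tell whether the aromatic ring or the linking amine hydrogen matters more, since the two change together.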